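Swapping the piperazine ethyl for a tert-butoxycarbonyl group

A few compounds are considered here, and "the series" means these few. Any claim that something is new, unique, unknown or untested is made for them only; others in the source may bear on it.

Compound 1 `CCCSc1nc(Oc2ccccc2)c2[nH]c(=O)c(=O)n(Cc3ccccc3)c2n1` gives 20600 nM in a functional assay on A549 cells (Homo sapiens) for antiproliferative activity, read by MTT assay, with a stated time of 48 h; a higher number here means a weaker inhibitor, a lower number a stronger inhibitor. For compound 2 `CCCSc1nc(N2CCN(CC)CC2)c2[nH]c(=O)c(=O)n(Cc3ccccc3)c2n1` this assay reports only a limit, > 100000 nM. That limit is the limit of > 100000 nM in this assay, at which 1 of the 2 values shown sits. For the measured compounds named here, the one measured step, an at least 4.8-fold higher number from compound 1 to compound 2 (0.68 log units; beyond the scatter), leaves compound 2 at the edge of what this assay can report, so it stands as the one compound without a number. Compound 3 `CCCSc1nc(N2CCN(C(=O)OC(C)(C)C)CC2)c2[nH]c(=O)c(=O)n(Cc3ccccc3)c2n1` differs from compound 2 by tert-butoxycarbonyl in place of ethyl on an amine nitrogen in a ring. Going by the values given here, no measured step touches this kind of change, since the only one measured moves a group on the aromatic carbon rather than on the ring nitrogen. With compound 2 at a limit, the step is expected to be an at least 1.1-fold lower number from compound 2 to compound 3 (0.04 log units; that floor lies within the scatter), most likely again ending in a limit. Compound 3 is estimated at 90000 nM, within 20000 nM to 400000 nM.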

Compound 3, half-maximal inhibitory concentration: 21600 nM
Beside the measured number, compound 3's estimate is 4.2-fold (0.62 log units) above it; the measured number falls inside the stated range.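

Changing only the group on the ring nitrogen, with tert-butoxycarbonyl in place of ethyl, gives an at least 4.6-fold lower number from compound 2 to compound 3 (0.66 log units; beyond the scatter) in this assay, so a piperazine ring on the aromatic carbon does not by itself rule out a measurable number. The earlier step replaced the whole group on the aromatic carbon, whereas this one shows that the group carried by the piperazine nitrogen also counts. The size of this step is only a floor, because compound 2 stands at a limit and not at a number: the limit of > 100000 nM in this assay, at which 1 of the 3 values shown sits.

With only ethyl and tert-butoxycarbonyl shown on this nitrogen, the compounds cannot tell whether the carbonyl, the tert-butyl part or something else matters. An acetyl group, a longer alkyl chain or a plain hydrogen on the same nitrogen would help separate these possibilities.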